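From a diethylamino chain to a dimethylamino chain

The source may report more compounds than this note shows. Statements on the series, on what has been measured and on what is new or still open speak of the compounds shown alone.

In a functional assay on cells (Homo sapiens) for antiproliferative activity, read by MTT assay, with a stated time of 48 h (a lower number here means a stronger inhibitor, a higher number a weaker inhibitor), compound 1 (`CN(C)CCCn1c(N)c(-c2nc3ccccc3[nH]2)c2nc(C#N)c(C#N)nc21`) gives 1820 nM and compound 2 (`CN(C)CCCn1c(N)c(-c2nc3ccccc3n2C)c2nc(C#N)c(C#N)nc21`) gives 3670 nM. Going by the values given here, the only measured step, a 2.0-fold higher number from compound 1 to compound 2 (0.30 log units; within the scatter), puts methyl in place of hydrogen on an aromatic nitrogen and leaves the chain untouched, so it says little about the change followed here.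

Compound 3 (`CCN(CC)CCn1c(N)c(-c2nc3cc(Cl)ccc3[nH]2)c2nc(C#N)c(C#N)nc21`) stands at > 50000 nM, which is a limit of the assay and not a number.

Compound 4 (`CN(C)CCCn1c(N)c(-c2nc3cc(Cl)ccc3[nH]2)c2nc(C#N)c(C#N)nc21`) differs from compound 3 only in the chain: (dimethylamino)methyl in place of diethylamino on a saturated chain carbon, two bonds along the chain from an aromatic nitrogen. Read one bond further out, 2-(diethylamino)ethyl becomes 3-(dimethylamino)propyl, the chain also carried by compound 1 and compound 2. Compound 4 keeps the chlorine of compound 3, which compound 1 lacks, so the comparison is imperfect. Among the compounds with values here, compound 1 reads 1820 nM with this chain, so a clearly lower number is expected in this assay, though no measured step isolates the chain. The expected change is an at least 10-fold lower number from compound 3 to compound 4 (1.00 log units; beyond the scatter). For compound 4 the estimated value is 5000 nM, with an expected range from 1200 nM to 30000 nM.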

Compound 4, half-maximal inhibitory concentration: 28100 nM
Estimate against measurement, compound 4: 5.6-fold (0.75 log units) below, within the range that was stated.
By their numbers in this assay, from the lowest: compounds 1 and 2 (each within the scatter of the next); then compound 4. At a limit, above all of these: compound 3.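

In this assay, the clearest new reading concerns the chlorine and not the chain: with 3-(dimethylamino)propyl held fixed, chloro in place of hydrogen on an aromatic carbon gives a 15-fold higher number from compound 1 to compound 4 (1.19 log units; beyond the scatter). Putting 5-chloro-1H-benzimidazol-2-yl in place of 1-methyl-1H-benzimidazol-2-yl gives a 7.7-fold higher number from compound 2 to compound 4 (0.88 log units; beyond the scatter), so the chlorinated compound reads higher than both chlorine-free compounds. The chain change itself stays loosely bounded, since compound 3 stands at a limit and not a number, which leaves only an at least 1.7-fold lower number from compound 3 to compound 4 (0.25 log units; that floor lies within the scatter): the limit of > 50000 nM in this assay, at which 1 of the 4 values shown sits.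

Still open, as far as these compounds go, is how far the chain change reaches once a true number replaces that limit, and whether the chlorine step holds on other chains. Also open, from the compounds shown here alone, is how a bromo or methoxy group in place of the chloro would read, or a longer chain ending in a morpholine.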